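The source may report more compounds than this note shows. Statements on the series, on what has been measured and on what is new or still open speak of the compounds shown alone.

Series notes: growth inhibition in a functional assay on U-251 cells (Homo sapiens) for inhibition, read by sulforhodamine B assay, with a stated time of 48 h; on this read-out lower numbers stand for stronger inhibition of growth and higher numbers for weaker inhibition of growth.

Compound 2 `Clc1ccc(Cn2cc(CCCOc3cccc4cccnc34)nn2)cc1` gives 3.4 ug/mL in this assay and stands lowest of the two numbers in hand, with compound 3 `Brc1ccc(Cn2cc(CCCOc3cccc4cccnc34)nn2)cc1` nearest at 8.4 ug/mL. Compound 1 `Ic1ccc(Cn2cc(CCCOc3cccc4cccnc34)nn2)cc1` returns only a limit, > 250 ug/mL, in this assay. All measured steps sit on the same aromatic carbon: an at least 73-fold lower number from compound 1 to compound 2 (1.86 log units; beyond the scatter) and an at least 29-fold lower number from compound 1 to compound 3 (1.47 log units; beyond the scatter) are both bounded by the limit of > 250 ug/mL in this assay, at which 1 of the 3 values shown sits, and so read only as large, while a 2.5-fold higher number from compound 2 to compound 3 (0.39 log units; beyond the scatter) is modest.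

Compound 4 `FC(F)(F)Oc1ccc(Cn2cc(CCCOc3cccc4cccnc34)nn2)cc1` differs from compound 2 by trifluoromethoxy in place of chloro on an aromatic carbon. For the measured compounds named here, none of the measured steps covers trifluoromethoxy; they show only that exchanging the group on this carbon has moved the number from a limit to a few units, and that even the change from chloro to bromo costs a 2.5-fold higher number from compound 2 to compound 3 (0.39 log units; beyond the scatter). Going by the values given here, with no closer precedent, the step is expected to go upward from compound 2, a 2.9-fold higher number from compound 2 to compound 4 (0.47 log units; beyond the scatter), with a wide range and a fair chance that this assay returns only a limit. Compound 4 is therefore expected at 10 ug/mL, within 2 ug/mL to 60 ug/mL.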

Compound 4, concentration for 50% growth inhibition: 9.8 ug/mL
For compound 4 the middle estimate is 1.0-fold (0.01 log units) above the measured one, within the range that was stated.
By their numbers in this assay, from the lowest: compound 2; then compounds 3 and 4 (each within the scatter of the next). At a limit, above all of these: compound 1.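

In this assay, trifluoromethoxy, with its five heavy atoms and one hydrogen-bond acceptor, keeps the number on this aromatic carbon in the measurable range, so this position is not limited to a single halogen atom: a 2.9-fold higher number from compound 2 to compound 4 (0.46 log units; beyond the scatter) is modest, and a 1.2-fold higher number from compound 3 to compound 4 (0.07 log units; within the scatter) does not separate the trifluoromethoxy compound from the bromo compound. Chloro in compound 2 remains the lowest of the measured numbers, now with steps beyond the scatter to all three other compounds. Iodo is thus the only group shown here that departs sharply from the others, and an at least 25-fold lower number from compound 1 to compound 4 (1.40 log units; beyond the scatter) reads only as a bound set by a limit: the limit of > 250 ug/mL in this assay, at which 1 of the 4 values shown sits.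

The compounds shown leave open whether groups on this carbon that contain no halogen, such as methoxy, an amine or a carboxylic acid, stay in this range, and whether fluoro or trifluoromethyl comes closer to chloro. Going by these compounds, every change shown sits on this one aromatic carbon, so how a longer chain to the shared core would behave with chloro in place also remains open.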